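Core substituent swap toward compound 4

A few compounds are considered here, and "the series" means these few. Any claim that something is new, unique, unknown or untested is made for them only; others in the source may bear on it.

Compound 1 `COc1cccc(CNCCCNc2ccnc3cc(C4CCCCC4)ccc23)c1O` gives 4200 nM in a physicochemical assay for solubility, with a stated time of 18 h, at pH 7.4; on this read-out higher numbers stand for higher solubility and lower numbers for lower solubility; compound 2 `COc1ccc(F)cc1CNCCCNc1ccnc2cc(C3CCCCC3)ccc12` gives 4200 nM; compound 3 `CC(C)(C)c1ccc(-c2ccc3c(NCCCNCc4ccco4)ccnc3c2)cc1` gives 32000 nM. Compound 2 stands level with compound 1, the two together the lowest of the three numbers, while compound 3 sits higher. Within the data shown here, the only single-place step, no change at the digits printed from compound 1 to compound 2 (within the scatter), concerns the saturated chain carbon bound to an amine nitrogen, not the core. Compound 4 `COc1ccc(F)cc1CNCCCNc1ccnc2cc(Oc3cccc(N(C)C)c3)ccc12` differs from compound 2 by 3-(dimethylamino)phenoxy in place of cyclohexyl on an aromatic carbon. Among the measured compounds shown here, no measured step touches this position, and compound 3 differs from compound 2 in more than one place, so the expectation rests on the change alone. A moderate rise in this assay is expected, a 2.9-fold higher number from compound 2 to compound 4 (0.46 log units; beyond the scatter), with wide uncertainty. Compound 4 is expected at 12000 nM, between 3000 nM and 50000 nM.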

Compound 4, solubility: 14500 nM
Compound 4: middle estimate off by 1.2-fold (0.08 log units), on the low side; low and high end bracket the measured number.
By their numbers in this assay, from the lowest: compounds 1 and 2 (each within the scatter of the next); then compound 4; then compound 3.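

The aromatic carbon that carried cyclohexyl now has a measured step: in this assay, 3-(dimethylamino)phenoxy in its place gives a 3.5-fold higher number from compound 2 to compound 4 (0.54 log units; beyond the scatter) on an otherwise unchanged structure. Among these compounds, the earlier single-place step touched only the saturated chain carbon bound to an amine nitrogen, so this is the first reading of a change on the shared core. Nothing measured here explains the shift. The compounds shown do not separate the contributions of the ether oxygen, the aromatic ring and the dimethylamino group. As far as these compounds go, whether a morpholine or a carboxylic acid on this carbon would move the number similarly remains open.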